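Chloro Substitution on Compound 1's Phenyl Ring

A few compounds are considered here, and "the series" means these few. Any claim that something is new, unique, unknown or untested is made for them only; others in the source may bear on it.

Measured compounds:
compound 1 `Cn1c(N2N=C(c3ccccc3)CC2c2ccc(F)cc2)nc(-c2ccccc2)c(C#N)c1=O` — 39200 nM
compound 2 `Cc1ccc(C2=NN(c3nc(-c4ccccc4)c(C#N)c(=O)n3C)C(c3ccc(F)cc3)C2)cc1` — 2000 nM

In a functional assay on A549 cells (Homo sapiens) for antiproliferative activity, with a stated time of 72 h (a higher number here means a weaker inhibitor, a lower number a stronger inhibitor), compound 1 gives 39200 nM, the highest of the two numbers, its nearest neighbour being compound 2 at 2000 nM. Compound 3 `Cn1c(N2N=C(c3ccccc3)CC2c2ccc(F)cc2)nc(-c2ccc(Cl)cc2)c(C#N)c1=O` arises from compound 1 by chloro in place of hydrogen on an aromatic carbon. Among the compounds with values here, the only measured step, a 20-fold lower number from compound 1 to compound 2 (1.29 log units; beyond the scatter), is a different change and bears on the present one only loosely; still, it shows that a single small aromatic substituent can move this series far. Within the data shown here, with no directly comparable step, a moderate fall in the number is expected for compound 3, within a wide range, a 2.6-fold lower number from compound 1 to compound 3 (0.42 log units; beyond the scatter). Compound 3 is therefore estimated at 15000 nM in this assay, between 4000 nM and 50000 nM.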

Compound 3, half-maximal inhibitory concentration: 27800 nM
For compound 3 the middle estimate is 1.9-fold (0.27 log units) below the measured one; measured number inside the range.
By their numbers in this assay, from the lowest: compound 2; then compounds 3 and 1 (each within the scatter of the next).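

In this assay, the change from phenyl to 4-chlorophenyl gives a 1.4-fold lower number from compound 1 to compound 3 (0.15 log units; within the scatter), so a chloro at this carbon, para to a large group, has no effect that can be told from the usual scatter. The earlier 20-fold lower number from compound 1 to compound 2 (1.29 log units; beyond the scatter) came from a methyl on a different aromatic ring, and the new result shows that a single small aromatic substituent does not move this series far in every case. No measurement is available that accounts for this result.

From the compounds shown here alone, whether an amine or a carboxylic acid at this same carbon would leave the number equally unmoved remains open. So does the question of what a chloro would do on the ring where compound 2 carries its methyl.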